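Purine benzamide series: chain in place of benzyl

The source may report more compounds than this note shows. Statements on the series, on what has been measured and on what is new or still open speak of the compounds shown alone.

Measured so far:
compound 1 `CN1CCN(c2nc(Cl)nc3c2ncn3Cc2ccc(C(=O)Nc3ccccc3N)cc2)CC1` — 55.1%
compound 2 `Nc1ccccc1NC(=O)c1ccc(Cn2cnc3c(Nc4ccc(-c5ccccn5)cc4)nc(Cl)nc32)cc1` — 30.8%
compound 3 `Nc1ccccc1NC(=O)c1ccc(CNc2nc(Cl)nc3c2ncn3Cc2ccccc2)cc1` — 46.4%

All three were run in a functional assay on NCI-H460 cells (Homo sapiens) for antiproliferative activity, read by CCK-8 assay, with a stated time of 72 h, tested at 8 uM; on this read-out higher numbers stand for a stronger effect at the one concentration tested and lower numbers for a weaker effect. Compound 3 stands second highest of the three numbers. Its nearest neighbour is compound 1, whose number is higher by an amount within the scatter, so no order between compound 1 and compound 3 can be stated. Compound 2 sits lower than compound 3 by an amount beyond the scatter.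

Compound 4 `COC(CCn1cnc2c(NCc3ccc(C(=O)Nc4ccccc4N)cc3)nc(Cl)nc21)OC` has not been measured. It differs from compound 3 in one place: 2,2-dimethoxyethyl in place of phenyl on a saturated chain carbon bound to an aromatic nitrogen. Going by the values given here, no pair of measured compounds differs in a single place, so no measured step bears directly on this change. The spread across the three measured numbers is modest, and the step of a number 6.4 percentage points lower from compound 3 to compound 4 (within the scatter) is expected to be small, toward a weaker effect if anything, and not beyond the scatter. For compound 4 the estimated value in this assay is 40%, with an expected range from 22% to 58%.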

Compound 4, a percentage reported as inhibition, at one concentration (the size of the read-out at that concentration, not a potency): 51.2%
Beside the measured number, compound 4's estimate is 11.2 percentage points below it; low and high end bracket the measured number.
By their numbers in this assay, from the lowest: compound 2; then compounds 3, 4 and 1 (each within the scatter of the next).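

In this assay the exchange of phenyl for 2,2-dimethoxyethyl on a saturated chain carbon bound to an aromatic nitrogen gives a number 4.8 percentage points higher from compound 3 to compound 4 (within the scatter). In this one pair, an open chain with no ring and with two hydrogen-bond acceptors therefore reads the same as the aromatic ring, so the ring is not needed at this position to hold the effect at the one concentration tested. Nothing at hand bears on the reason for this outcome.

Still open, as far as these compounds go, is whether the two methoxy groups contribute at all, which a plain alkyl chain would test, and how a chain ending in a tertiary amine or a carboxylic acid would read here. Also open, from the compounds shown here alone, is whether the exchange reads the same with the other groups on the shared core seen in compound 1 and compound 2.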